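Swapping a Sulfonyl Chain for a Diethylamino Group

The source may hold more compounds than are shown below. What is called first, only, known or untested is meant among the compounds shown, and "the series" means these compounds.

Compound 1 `CCS(=O)(=O)N1CCN(c2ccc(OCC3CCN(C(=O)OC(C)C)CC3)cn2)CC1`: 1300 nM
Compound 2 `CCCCS(=O)(=O)N1CCN(c2ccc(OCC3CCN(C(=O)OC(C)C)CC3)cn2)CC1`: 100 nM
Compound 3 `COCCS(=O)(=O)N1CCN(c2ccc(OCC3CCN(C(=O)OC(C)C)CC3)cn2)CC1`: 300 nM

These three compounds share one core and differ only in the group attached to the sulfonyl sulfur. In a functional assay on CHO-K1 cells for agonist activity at Glucose-dependent insulinotropic receptor (Homo sapiens), read by a luciferase reporter, with a stated time of 5 h (on this read-out higher numbers stand for an effect only at larger amounts of compound and lower numbers for an effect already at smaller amounts), compound 3 gives 300 nM, the second highest of the three numbers: compound 2 stands nearest, with a 3.0-fold higher number from compound 2 to compound 3 (0.48 log units; beyond the scatter), and compound 1 furthest, with a 4.3-fold lower number from compound 1 to compound 3 (0.64 log units; beyond the scatter).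

Compound 4 `CCN(CC)S(=O)(=O)N1CCN(c2ccc(OCC3CCN(C(=O)OC(C)C)CC3)cn2)CC1` carries diethylamino in place of 2-methoxyethyl on a sulfonyl sulfur. Going by the values given here, no measured step exchanges the carbon chain on the sulfonyl sulfur for a nitrogen-linked group, so the only guidance comes from the steps that enlarge that chain: a 13-fold lower number from compound 1 to compound 2 (1.11 log units; beyond the scatter) and a 4.3-fold lower number from compound 1 to compound 3 (0.64 log units; beyond the scatter), both lowering the number. The diethylamino group is comparable in size to the butyl chain of compound 2. A modest lowering of the number from compound 3 is therefore expected, a 2.0-fold lower number from compound 3 to compound 4 (0.30 log units; within the scatter), with real uncertainty from the changed attachment atom. Compound 4 is estimated at 150 nM, in a range from 50 nM to 600 nM.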

Compound 4, half-maximal effective concentration: 1200 nM
The estimate for compound 4 lay 8.0-fold (0.90 log units) below the measured number, and the stated range ends below it.
By their numbers in this assay, from the lowest: compound 2; then compound 3; then compounds 4 and 1 (each within the scatter of the next).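

On the sulfonyl sulfur, the outcome in (this assay) does not follow the number of heavy atoms alone: diethylamino has more of them than 2-methoxyethyl, yet replacing that chain gives a 4.0-fold higher number from compound 3 to compound 4 (0.60 log units; beyond the scatter) and replacing butyl gives a 12-fold higher number from compound 2 to compound 4 (1.08 log units; beyond the scatter). Replacing ethyl gives a 1.1-fold lower number from compound 1 to compound 4 (0.03 log units; within the scatter), so the benefit of going from ethyl to butyl does not carry over to diethylamino, which brings a nitrogen to the sulfonyl sulfur in place of a carbon. Nothing measured here gives a reason for this difference.

As far as these compounds go, it remains open whether the attached nitrogen itself or the two ethyl arms on it set this result, a question that dimethylamino or pyrrolidinyl on the sulfonyl sulfur would address. Also open, from the compounds shown here alone, is whether a longer chain, such as pentyl, would lower the number further than butyl.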